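Swapping a phenyl for a pyridin-2-yl on the core nitrogen

The source may hold more compounds than are shown below. What is called first, only, known or untested is meant among the compounds shown, and "the series" means these compounds.

The compounds share one core; compound 1 `Nc1c2c(=O)[nH]c(-c3ccccc3)cc2nn1-c1ccccc1` carries a phenyl on each of two positions. In an assay on isolated protein for inhibition of serine/threonine-protein kinase Chk2 (Homo sapiens), read by mobility shift assay, tested at 30 uM (a higher number here means more inhibition at the concentration tested (going by the name of the read-out), a lower number less inhibition), compound 1 gives -8%, the lowest of the two numbers at hand. Compound 2 `Nc1c2c(=O)[nH]c(-c3ccccn3)cc2nn1-c1ccccc1`, with pyridin-2-yl in place of phenyl on an aromatic carbon, gives 3% in this assay, a step of a number 11 percentage points higher from compound 1 to compound 2 (beyond the scatter).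

Compound 3 `Nc1c2c(=O)[nH]c(-c3ccccc3)cc2nn1-c1ccccn1` makes the corresponding swap at the other phenyl: pyridin-2-yl in place of phenyl on an aromatic nitrogen. Going by the values given here, no measured step covers this exact change; the only related one is the modest rise from compound 1 to compound 2 at the carbon position. Going by that, a small upward step beyond the scatter is expected in this assay, a number 10 percentage points higher from compound 1 to compound 3 (within the scatter), with much uncertainty. Compound 3 is therefore estimated at 2%, within a range of -12% to 16%.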

Compound 3, a percentage reported as inhibition, at one concentration (the size of the read-out at that concentration, not a potency): 18%
For compound 3 the middle estimate is 16 percentage points below the measured one, outside the stated range (above it).
By their numbers in this assay, from the lowest: compound 1; then compound 2; then compound 3.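

In this assay pyridin-2-yl in place of phenyl on the aromatic nitrogen gives a number 26 percentage points higher from compound 1 to compound 3 (beyond the scatter) and so shows that this position, too, responds to a phenyl-to-pyridin-2-yl swap. The earlier compounds shown here showed such a rise only on the aromatic carbon. Even so, compound 3 reads 18% and this is a modest inhibition at one concentration rather than a potency, while nothing available explains the rise.

Open is whether the gain depends on where the ring nitrogen sits, since pyridin-3-yl and pyridin-4-yl are absent from the compounds shown. Also open, as far as these compounds go, is what a pyridin-2-yl on both positions would give, or an amine or a carboxylic acid on the ring at this position.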